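The compounds below may be only part of what the source reports. "The series", "measured", "known", "first", "only" and "open" are said of these compounds alone.

Within the data shown here, in an ADME assay on HEK-293T cells (Homo sapiens) for cytotoxicity, read by luminescence, with a stated time of 24 h (on this read-out higher numbers stand for lower toxicity in this test and lower numbers for higher toxicity in this test), the three compounds measured so far all sit at the same kind of reading. Compound 1 (`COc1ccc(Cn2c(C(N)=O)cc3sccc32)cc1`) gives > 100000 nM, which is a limit of the assay and not a number. Compound 2 (`COc1ccc(Cn2c(C(=O)NCc3ccccc3)cc3sccc32)cc1`) gives > 100000 nM, again a limit. Compound 3 (`COc1ccc(Cn2c(C(=O)N3CCC(C(=O)NCc4ccccc4)CC3)cc3sccc32)cc1`) gives > 100000 nM, and this too is only a limit, so its place among the values shown cannot be read more finely.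

Compound 4 (`COc1ccc(Cn2c(C(=O)N3CCC(C(=O)NCC4CC4)CC3)cc3sccc32)cc1`) is the next to be measured, and the structural change is cyclopropyl in place of phenyl on a saturated chain carbon bound to an amide-type nitrogen. In words, this is cyclopropyl in place of phenyl on a saturated chain carbon bound to an amide-type nitrogen, so that benzylcarbamoyl becomes (cyclopropylmethyl)carbamoyl.

Among the measured compounds shown here, no measured step makes this same exchange. The nearest is a step that the two limits leave unreadable from compound 1 to compound 2, which also concerns a group on an amide-type nitrogen but yields no size to carry over. The evidence available is the limit of > 100000 nM in this assay, at which 3 of the 3 values shown sit. In this assay, no step beyond the usual scatter is therefore expected, and no direction can be favoured. The expected step is a number no higher from compound 3 to compound 4 (the limit leaves the size open). For compound 4 the estimate is 100000 nM, with an expected range from 50000 nM to 200000 nM.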

Compound 4, half-maximal cytotoxic concentration: 24600 nM
The estimate for compound 4 lay 4.1-fold (0.61 log units) above the measured number, and the stated range ends above it.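

At the position on a saturated chain carbon bound to an amide-type nitrogen, cyclopropyl in place of phenyl gives an at least 4.0-fold lower number from compound 3 to compound 4 (0.60 log units; beyond the scatter) in this assay, so the group carried on this amide-type nitrogen can move the read-out. From the compounds shown here alone, since a lower number stands for higher toxicity in this test, the change from benzylcarbamoyl to (cyclopropylmethyl)carbamoyl goes towards higher toxicity, although the full size of the step stays open. Compound 4 is the only compound shown that gives a number rather than a limit, which makes this the first readable step in the series: the limit of > 100000 nM in this assay, at which 3 of the 4 values shown sit.

The compounds shown leave open whether the step follows the loss of the six-membered aromatic ring or the arrival of the three-membered ring, a question that a cyclohexyl group or an open butyl chain at the same place would address. They also leave open whether an amine or a carboxylic acid on this chain would lower the number in the same way, and whether the same exchange would count for anything on compound 2, which carries the benzyl group without the intervening ring.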